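Fluoro on the benzoyl ring: cytotoxicity in Vero cells

The compounds below may be only part of what the source reports. "The series", "measured", "known", "first", "only" and "open" are said of these compounds alone.

Measured compounds:
Compound 1 `CN(C)c1cc2[nH]c(C3CCCCC3)nc2cc1NC(=O)c1ccccc1` — in an ADME assay on Vero cells (Chlorocebus sabaeus) for cytotoxicity, read by resazurin assay, with a stated time of 3 days (a higher number here means a weaker inhibitor, a lower number a stronger inhibitor), compound 1 gives > 100 ug/mL.
Compound 2 `CCCNC(=O)Nc1cc2nc(C3CCCCC3)[nH]c2cc1N(CC)CC` — in this assay compound 2 gives > 100 ug/mL.
Compound 3 `CCOCCOC(=O)Nc1cc2nc(C3CCCCC3)[nH]c2cc1N1CCCC1` — in this assay compound 3 gives > 100 ug/mL.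

Each of these three values is a limit of the assay rather than a number. Compound 1 therefore stands at the limit of > 100 ug/mL in this assay, at which 3 of the 3 values shown sit, and no difference between compound 1, compound 2 and compound 3 can be read from these results.

Compound 4 `CN(C)c1cc2[nH]c(C3CCCCC3)nc2cc1NC(=O)c1ccc(F)cc1` is the next compound to be measured in this assay. It differs from compound 1 by fluoro in place of hydrogen on an aromatic carbon. Within the data shown here, no measured pair of compounds shows what such a change does in this assay, so the expectation rests on the limits alone. Compound 4 is expected to give 150 ug/mL, within 60 ug/mL to 400 ug/mL. The step that the limit leaves unreadable from compound 1 to compound 4 is thus expected to be none beyond the scatter, with compound 4 most likely reported again only as a limit.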

Compound 4, half-maximal inhibitory concentration: > 100 ug/mL
Compound 4: no number, only a limit; the forecaster's own chance of this, stated with the estimate: 85%; the middle value does not contradict the limit.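

In this assay compound 4 gives > 100 ug/mL as a limit of the assay and not a number. Compound 1 also stands at a limit, so no step can be read between compound 1 and compound 4. The compounds shown leave open whether fluoro in place of hydrogen changes cytotoxicity at all.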